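Swapping the aryl group on the hydrazone carbon

A few compounds are considered here, and "the series" means these few. Any claim that something is new, unique, unknown or untested is made for them only; others in the source may bear on it.

Compound 1 `CN(C)CCn1cnnc1-c1cc(Oc2ccc(NC(=O)N/N=C/c3ccc(O)c(Br)c3)cc2F)ccn1` gives the lowest number among the three measured compounds in a functional assay on HT-29 cells (Homo sapiens) for cytotoxicity, read by MTT assay, with a stated time of 72 h (a higher number here means a weaker inhibitor, a lower number a stronger inhibitor), namely 450 nM. Compound 2 `CN(C)CCn1cnnc1-c1cc(Oc2ccc(NC(=O)N/N=C/c3ccc(F)cc3)cc2F)ccn1` gives 1370 nM, and compound 3 `CN(C)CCn1cnnc1-c1cc(Oc2ccc(NC(=O)N/N=C/c3c(O)ccc4ccccc34)cc2F)ccn1` gives 670 nM. The step of a 3.0-fold higher number from compound 1 to compound 2 (0.48 log units; beyond the scatter) is beyond the scatter, whereas the step of a 1.5-fold higher number from compound 1 to compound 3 (0.17 log units; within the scatter) is within it. Compound 4 `COc1ccc(/C=N/NC(=O)Nc2ccc(Oc3ccnc(-c4nncn4CCN(C)C)c3)c(F)c2)cc1O` differs from compound 1 in one place: 3-hydroxy-4-methoxyphenyl in place of 3-bromo-4-hydroxyphenyl on a carbon with a double bond to nitrogen. Both steps from compound 1 bear on this change, since each replaces the same group on a carbon with a double bond to nitrogen; the larger loss came with compound 2, the smaller with compound 3. A small weakening, expected near the edge of the scatter, is therefore estimated as a 1.4-fold higher number from compound 1 to compound 4 (0.16 log units; within the scatter). Compound 4 is expected to give about 650 nM, plausibly between 300 nM and 1400 nM.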

Compound 4, half-maximal inhibitory concentration: 960 nM
The estimate for compound 4 lay 1.5-fold (0.17 log units) below the measured number; the range from low to high includes it.
By their numbers in this assay, from the lowest: compounds 1, 3, 4 and 2 (each within the scatter of the next, the first and the last beyond it).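

In this assay, the step to 3-hydroxy-4-methoxyphenyl is a 2.1-fold higher number from compound 1 to compound 4 (0.33 log units; beyond the scatter) and lies beyond the scatter, so a hydroxy group on the aryl ring does not by itself keep the number of compound 1. Compound 4 is not separated from the other two, with a 1.4-fold higher number from compound 3 to compound 4 (0.16 log units; within the scatter) and a 1.4-fold lower number from compound 2 to compound 4 (0.15 log units; within the scatter) both within the scatter, even though compound 2 carries no hydroxy group. Nothing shown explains these differences. Still open, as far as these compounds go, is how a 3-bromophenyl group without the hydroxy, or a 4-aminophenyl group, would compare at this carbon.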